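Methoxy for hexylamino on the carbonyl of compound 1

This account rests on a few compounds, and the source may have more. Where it says the series, first, only, none or still open, it means among the compounds named here.

Compound 1 `CCCCCCNC(=O)c1cc(C#Cc2cc(OC)ccc2OC)ccc1OC` gives 56800 nM
Compound 2 `CCCCCCNC(=O)c1cc(/C=C\c2cc(O)ccc2O)ccc1O` gives 5800 nM
Compound 3 `CCCCCCNC(=O)c1cc(/C=C\c2cc(OC)ccc2OC)ccc1OC` gives 25000 nM

All three values come from a functional assay on UACC-62 cells (Homo sapiens) for antiproliferative activity; a higher number here means a weaker inhibitor of growth, a lower number a stronger inhibitor of growth. Compound 1 gives 56800 nM, the highest of the three numbers and so the weakest growth inhibition in this small set. Compound 3 is the nearest at 25000 nM, and compound 2 is the furthest at 5800 nM. Both gaps from compound 1 lie beyond the usual scatter.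

The next compound is compound 4 `COC(=O)c1cc(C#Cc2cc(OC)ccc2OC)ccc1OC`, which keeps the core of compound 1 and carries methoxy in place of hexylamino on a carbonyl carbon. The same difference reads as hexylcarbamoyl to methoxycarbonyl. Among the compounds with values here, all three measured compounds carry hexylamino, so no measured pair shows what this replacement does in this assay. With nothing to size the change, the working expectation is no step beyond the scatter, and compound 1 at 56800 nM serves as the anchor. The expected result is a 1.1-fold higher number from compound 1 to compound 4 (0.06 log units; within the scatter). For compound 4 the estimated value is 65000 nM, with an expected range of 25000 nM to 100000 nM.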

Compound 4, concentration for 50% growth inhibition: 29300 nM
Compound 4: middle estimate off by 2.2-fold (0.35 log units), on the high side; measured number inside the range.
By their numbers in this assay, from the lowest: compound 2; then compounds 3, 4 and 1 (each within the scatter of the next, the first and the last beyond it).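

In this assay, within the data shown here, the first measured step at this carbonyl carbon is small: methoxy in place of hexylamino gives (a 1.9-fold lower number from compound 1 to compound 4 (0.29 log units; within the scatter)), which lies within the scatter. On the core of compound 1, the hexylcarbamoyl group can therefore give way to methoxycarbonyl with no resolved effect on growth inhibition, even though the exchange removes the hexyl chain and the amide hydrogen, so neither feature is shown to be needed at this level of activity. No supporting data bear on why the two groups read alike, and this single pair offers no explanation.

The compounds shown leave open whether a carboxylic acid, an unsubstituted amide or a longer chain on this carbonyl carbon would produce a step beyond the scatter, since methoxy is the only replacement for hexylamino seen so far. From the compounds shown here alone, it also remains open whether methoxy in place of hexylamino would behave the same way on the cores of compound 2 and compound 3, so the present reading holds only for the core of compound 1.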